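Trifluoromethylphenyl Replacing Dichlorophenyl on the Shared Core

The source may report more compounds than this note shows. Statements on the series, on what has been measured and on what is new or still open speak of the compounds shown alone.

Measured so far:
compound 1, `CCCS(=O)(=O)Nc1ccc(F)c(C(=O)c2n[nH]c3ncc(-c4cccc(O)c4)cc23)c1F`, 2.2%
compound 2, `CCCS(=O)(=O)Nc1ccc(F)c(C(=O)c2n[nH]c3ncc(-c4ccc(Cl)c(Cl)c4)cc23)c1F`, 45%

In an assay for binding affinity to dual specificity mitogen-activated protein kinase kinase 4 (Homo sapiens), read by KINOMEscan, tested at 100 nM (a higher number here means a weaker effect of the compound at the concentration tested, a lower number a stronger effect), compound 1 gives 2.2%. For the measured compounds named here, compound 2 stands highest of the two numbers measured; its nearest neighbour is compound 1, and the single step of a number 42.8 percentage points higher from compound 1 to compound 2 (beyond the scatter) lies beyond the scatter. Compound 3, `CCCS(=O)(=O)Nc1ccc(F)c(C(=O)c2n[nH]c3ncc(-c4cccc(C(F)(F)F)c4)cc23)c1F`, has not yet been measured. It differs from compound 2 in one place: 3-(trifluoromethyl)phenyl in place of 3,4-dichlorophenyl on an aromatic carbon. Going by the values given here, only the step from compound 1 to compound 2 bears on this change, and it shows that exchanging the group at this position can move the read-out by a large amount. With both compound 2 and compound 3 carrying groups that count no hydrogen-bond donors or acceptors, the estimate a number 15 percentage points lower from compound 2 to compound 3 (beyond the scatter) is expected to be a modest fall, with wide uncertainty. Compound 3 is therefore expected to give 30%, between 5% and 70%.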

Compound 3, a percentage reported as activity, at one concentration (the size of the read-out at that concentration, not a potency): 57%
Compound 3: middle estimate off by 27 percentage points, on the low side; the measured number falls inside the stated range.
By their numbers in this assay, from the lowest: compound 1; then compound 2; then compound 3.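

In this assay, 3-(trifluoromethyl)phenyl in place of 3,4-dichlorophenyl gives a number 12 percentage points higher from compound 2 to compound 3 (beyond the scatter) and so shows that this second group, also counted with no hydrogen-bond donors or acceptors, does not bring the read-out back towards that of compound 1. Set directly against the hydroxy group of compound 1, trifluoromethyl gives a number 54.8 percentage points higher from compound 1 to compound 3 (beyond the scatter) in the same read-out, so among the three compounds shown, the hydroxy compound remains far the strongest. Nothing measured here accounts for these differences.

The compounds shown leave open how an amine or a carboxylic acid on this aromatic ring would read. They also leave open whether a methoxy group or a single chlorine would stand nearer to compound 1 or to compound 3.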